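A few compounds are considered here, and "the series" means these few. Any claim that something is new, unique, unknown or untested is made for them only; others in the source may bear on it.

Measured compounds:
compound 1 (`COC(=O)c1ccc(COc2ccc(CNC(=O)[C@@H]3CCC(=O)N3Cc3ccccc3)cc2)cc1`): > 5000 nM
compound 2 (`O=C(O)c1ccc(COc2ccc(CNC(=O)[C@@H]3CCC(=O)N3Cc3ccccc3)cc2)cc1`): 4500 nM

In an assay on HEK293 cells for inhibition of Ataxin-2 (Mus musculus), read by fluorescence and Amplex Red (on this read-out higher numbers stand for weaker inhibition and lower numbers for stronger inhibition), compound 1 gives > 5000 nM, which is a limit of the assay and not a number. In this assay, within the data shown here, compound 2 gives 4500 nM, the only number obtained so far. Among the measured compounds shown here, the one further value, that of compound 1, is a limit of the assay. For the measured compounds named here, the single measured step, an at least 1.1-fold lower number from compound 1 to compound 2 (0.04 log units; that floor lies within the scatter), is a change of hydrogen in place of methyl on an oxygen next to a carbonyl group; since compound 1 sits at the limit of > 5000 nM in this assay, at which 1 of the 2 values shown sits, only a floor for that step is known, and that floor lies within the scatter.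

Compound 3 (`O=C(NCc1ccc(O)cc1)[C@@H]1CCC(=O)N1Cc1ccccc1`) awaits measurement in this assay. It differs from compound 2 by hydrogen in place of 4-carboxybenzyl on an oxygen on an aromatic ring. Going by the values given here, no measured step touches an oxygen on an aromatic ring, so none of the data bears directly on this change; the only measured step concerns a different place and was itself within the scatter. Compound 3 is therefore expected to show a step of a 1.6-fold higher number from compound 2 to compound 3 (0.19 log units; within the scatter) in this assay, toward a higher number but possibly within the scatter. Compound 3 is estimated at 7000 nM, between 2500 nM and 20000 nM.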

Compound 3, half-maximal inhibitory concentration: > 5000 nM
Compound 3: only a limit was reported (the forecaster's own chance of this, stated with the estimate: 55%); the middle value is on the limit's open side.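

Among these compounds, the first change at this place, hydrogen in place of 4-carboxybenzyl on an oxygen on an aromatic ring, gives in this assay an at least 1.1-fold higher number from compound 2 to compound 3 (0.04 log units; that floor lies within the scatter). Compound 3 gives > 5000 nM, which is a limit of the assay and not a number. Only a floor is therefore known for the loss of the 4-carboxybenzyl group, so the true size of this step stays open, the step between compound 1 and compound 3 cannot be read, and the series now rests mostly on one end of the read-out: the limit of > 5000 nM in this assay, at which 2 of the 3 values shown sit.

The compounds shown leave open what a smaller group on this oxygen, such as methyl or benzyl, would do to the number in this assay, and whether an amine or a tetrazole could stand in place of the carboxylic acid of the 4-carboxybenzyl group. They also leave open whether any change at this place can give a number clearly lower than that of compound 2, which gives 4500 nM.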